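Chloro in Place of Trifluoromethyl on the Aryl Urea

This account rests on a few compounds, and the source may have more. Where it says the series, first, only, none or still open, it means among the compounds named here.

Compound 1 `COc1cc2cc(Oc3ccc(NC(=O)Nc4cccc(C(F)(F)F)c4)cc3)c(C)nc2cc1OC` and compound 2 `COc1cc2cc(Oc3ccc(NC(=O)Nc4ccc(Cl)c(C(F)(F)F)c4)cc3)c(C)nc2cc1OC` share a core and differ only at the outer aryl ring of the urea. In a functional assay on RXF 393 cells (Homo sapiens) for inhibition, read by sulforhodamine B assay, with a stated time of 48 h (a lower number here means a stronger inhibitor of growth, a higher number a weaker inhibitor of growth), compound 1 gives 4970 nM, and compound 2 gives 4210 nM. For the measured compounds named here, the step of a 1.2-fold lower number from compound 1 to compound 2 (0.07 log units; within the scatter) is the only measured step and it is within the scatter, so it tells little about direction. On the two numbers shown, compound 2 has the lower figure, though not distinguishably so from compound 1. Compound 3 `COc1cc2cc(Oc3ccc(NC(=O)Nc4ccc(Cl)c(Cl)c4)cc3)c(C)nc2cc1OC` carries the change (chloro in place of trifluoromethyl on an aromatic carbon). No measured step touches this change, and the one step available was small, so the size of any step in this assay cannot be read from the numbers shown. Compound 3 is therefore expected to stay close to compound 2, with the step of a 1.3-fold higher number from compound 2 to compound 3 (0.12 log units; within the scatter) estimated to lie within the scatter. The estimate for compound 3 is 5500 nM, with a range from 2500 nM to 12000 nM.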

Compound 3, concentration for total growth inhibition: 16700 nM
Compound 3: the middle estimate sits 3.0-fold (0.48 log units) below what was measured; the whole stated range lies below it.
By their numbers in this assay, from the lowest: compounds 2 and 1 (each within the scatter of the next); then compound 3.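

In this assay, adding chloro to the aryl ring had stayed within the scatter, but replacing trifluoromethyl with chloro on an aromatic carbon, ortho to a chloro group, gives a 4.0-fold higher number from compound 2 to compound 3 (0.60 log units; beyond the scatter), which shows that the number does respond to the group at this place. The change also separates compound 3 from the compound without the second ring substituent, with a 3.4-fold higher number from compound 1 to compound 3 (0.53 log units; beyond the scatter), so among these compounds, the two carrying trifluoromethyl stay within the scatter of each other while the 3,4-dichlorophenyl compound stands apart as the weakest inhibitor of growth. Nothing available here accounts for this step.

The compounds shown leave open how other groups at this place, such as methyl, methoxy or nitrile, would stand relative to trifluoromethyl and chloro. They also leave open how the 4-chlorophenyl urea, with hydrogen at this place, would compare.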